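The source may report more compounds than this note shows. Statements on the series, on what has been measured and on what is new or still open speak of the compounds shown alone.

Compound 1 `COc1ccc(C2=C(c3cc(OC)c(OC)c(OC)c3)CC3CCCN3C2=O)cc1O`: > 100000 nM, a limit of the assay
Compound 2 `COc1ccc(C2=C(c3ccc(SC)cc3)CC3CCCN3C2=O)cc1OC(=O)CNC(=O)OC(C)(C)C`: 20000 nM
Compound 3 `COc1ccc(C2=C(c3ccc(SC)cc3)CC3CCCN3C2=O)cc1Br`: 3000 nM

In a functional assay on SK-OV-3 cells (Homo sapiens) for cytotoxicity (on this read-out lower numbers stand for stronger inhibition of growth and higher numbers for weaker inhibition of growth), compound 3, at 3000 nM, holds the lower of the two actual numbers. Compound 4 `CSc1ccc(C2=C(c3ccc(F)c(F)c3)C(=O)N3CCCC3C2)cc1` departs from it as follows: 3,4-difluorophenyl in place of 3-bromo-4-methoxyphenyl on a double-bonded ring carbon. Among the compounds with values here, the one measured step, a 6.7-fold lower number from compound 2 to compound 3 (0.82 log units; beyond the scatter), is modest and falls on the very group that now leaves whole. Within the data shown here, no measurement covers this exchange itself, so that size is the only guide, and a modest move toward a higher number is expected. Going by these compounds, the upper end stays open, given (the limit of > 100000 nM in this assay, at which 1 of the 3 values shown sits). The expected change is a 4.0-fold higher number from compound 3 to compound 4 (0.60 log units; beyond the scatter). For compound 4 the estimate is 12000 nM, with an expected range of 3000 nM to 60000 nM.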

Compound 4, concentration for 50% growth inhibition: 100 nM
Estimate against measurement, compound 4: 120-fold (2.08 log units) above; measured number outside the range, below it.
By their numbers in this assay, from the lowest: compound 4; then compound 3; then compound 2. At a limit, above all of these: compound 1.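

In this assay, the double-bonded ring carbon tolerates replacement of the whole aryl group, and 3,4-difluorophenyl in place of 3-bromo-4-methoxyphenyl gives a 30-fold lower number from compound 3 to compound 4 (1.48 log units; beyond the scatter), with the 4-(methylsulfanyl)phenyl group unchanged. This large step exceeds the modest earlier change on the same aryl ring, a 6.7-fold lower number from compound 2 to compound 3 (0.82 log units; beyond the scatter), so exchanging the ring's full substitution moves the number further than that single replacement. No measured property at hand accounts for the step. The compounds shown do not separate the loss of bromine from the loss of methoxy or the entry of fluorine. Going by these compounds, how an amine or a carboxylic acid on this ring would read stays open.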